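A few compounds are considered here, and "the series" means these few. Any claim that something is new, unique, unknown or untested is made for them only; others in the source may bear on it.

Measured compounds in this series:
compound 1, `Cc1cc(N2CCN(C)CC2)cn2c(CSCCc3ccccc3)cnc12`, 32 ug/mL
compound 2, `Cc1cc(N2CCCC2=O)cn2c(CSCCc3ccccc3)cnc12`, 89 ug/mL
compound 3, `Cc1cc(N2CCN(C)CC2)c2ncc(CSCCc3ccccc3)n2c1`, "not determined" (no result reported)

In an ADME assay on HEL cells (Homo sapiens) for cytotoxicity, with a stated time of 3 days (on this read-out lower numbers stand for higher toxicity in this test and higher numbers for lower toxicity in this test), compound 1 gives 32 ug/mL. In the same test compound 2 gives 89 ug/mL. The step between them, a 2.8-fold higher number from compound 1 to compound 2 (0.44 log units; beyond the scatter), goes with the change (2-oxopyrrolidin-1-yl in place of 4-methylpiperazin-1-yl on an aromatic carbon).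

Compound 3 has the same atoms as compound 1 joined differently; the difference between the two cores is not broken down here. In this assay compound 3 is recorded as "not determined" (no result reported), so nothing can be said of where it stands.

Compound 4, `Cc1cc(N2CCCC2=O)c2ncc(CSCCc3ccccc3)n2c1`, is not yet measured. It differs from compound 3 by 2-oxopyrrolidin-1-yl in place of 4-methylpiperazin-1-yl on an aromatic carbon. The surroundings of the place are not the same word for word: in compound 3 the place is ortho to a fused ring, whereas in compound 1 it is para to a fused ring; the rest of the place description agrees. The change from compound 3 to compound 4 is therefore the same kind of change as that from compound 1 to compound 2, not the same change.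

Without a value for compound 3 no step size can be anchored for compound 4. The expectation for compound 4 rests on compound 2, which carries the same entering group and gives 89 ug/mL in this assay. Compound 4 is expected to come out near 75 ug/mL, with an estimated range from 30 ug/mL to 160 ug/mL.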

Compound 4, half-maximal cytotoxic concentration: 25 ug/mL
Estimate against measurement, compound 4: 3.0-fold (0.48 log units) above; the whole stated range lies above it.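

In this assay, for the compounds shown here, compound 3 has no reported result, so no step from compound 3 to compound 4 can be read, although compound 4 gives 25 ug/mL. The compounds shown leave open whether 2-oxopyrrolidin-1-yl in place of 4-methylpiperazin-1-yl, ortho to a fused ring, moves the read-out as it does on the core of compound 1. No supporting data bear on this result.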